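The source may hold more compounds than are shown below. What is called first, only, known or untested is meant among the compounds shown, and "the series" means these compounds.

In a functional assay on MGC-803 cells (Homo sapiens) for antiproliferative activity, read by MTT assay, with a stated time of 48 h (a lower number here means that less compound is needed, a higher number that more compound is needed for the effect), compound 1 `CC1=NN(S(=O)(=O)c2ccccc2)C(c2cc(Br)ccc2O)C1` gives > 60000 nM, which is a limit and not a number. Compound 2 `CC1=NN(S(=O)(=O)c2ccccc2C)C(c2cc(Br)ccc2O)C1` gives > 60000 nM, again a limit. That is all the measurements show so far: the limit of > 60000 nM in this assay, at which 2 of the 2 values shown sit. For the measured compounds named here, the one measured step, a step that the two limits leave unreadable from compound 1 to compound 2, therefore has no size that can be read and points in no direction. Compound 3 `CC1=NN(S(=O)(=O)c2ccc(C(F)(F)F)cc2)C(c2cc(Br)ccc2O)C1` departs from compound 1 by trifluoromethyl in place of hydrogen on an aromatic carbon, with trifluoromethyl in place of hydrogen on an aromatic carbon, para to a large group. Going by the values given here, no measured step argues for a shift, so no change beyond the scatter is expected in this assay. The expected move is a number no higher from compound 1 to compound 3 (the limit leaves the size open). For compound 3 the estimated value is 60000 nM, with an expected range from 25000 nM to 120000 nM. A further limit rather than a number is also quite likely.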

Compound 3, half-maximal effective concentration: 30000 nM
Estimate against measurement, compound 3: 2.0-fold (0.30 log units) above; measured number inside the range.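

In this assay, for the compounds shown here, trifluoromethyl in place of hydrogen, para to a large group, yields the first step with a readable size: an at least 2.0-fold lower number from compound 1 to compound 3 (0.30 log units; that floor lies within the scatter). Going by these compounds alone, compound 3 is the only one of the three compounds to give a number rather than a limit: the limit of > 60000 nM in this assay, at which 2 of the 3 values shown sit. The step from compound 1 to compound 2 cannot be read, whereas this change shows that a substituent at this place on the aromatic ring can bring the value into the readable range, although the printed floor alone does not establish a change beyond the scatter.

From the compounds shown here alone, the true size of the step stays open, since compound 1 gives only a limit. Going by these compounds, it is also open whether a methyl, a chlorine atom, a methoxy group or an amine at the same place would give a number, or whether this is particular to trifluoromethyl.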